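The source may report more compounds than this note shows. Statements on the series, on what has been measured and on what is new or still open speak of the compounds shown alone.

Series so far in a functional assay (aorta) with Oryctolagus cuniculus as the target; a higher number here means a weaker inhibitor, a lower number a stronger inhibitor
- compound 1 `CCO/C(O)=C1\C(C)=NC(C)=C(C(=O)OCCCN2C(=O)c3ccccc3S2(=O)=O)C1c1ccccc1[N+](=O)[O-]` gives 2.6 nM
- compound 2 `CC1=NC(C)=C(C(=O)OCCCN2C(=O)c3ccccc3S2(=O)=O)C(c2ccccc2[N+](=O)[O-])/C1=C(\O)OC(C)C` gives 1.2 nM
- compound 3 `CC1=NC(C)=C(C(=O)OCCCN2C(=O)c3ccccc3S2(=O)=O)C(c2ccccc2[N+](=O)[O-])/C1=C(\O)OCC1CCCO1` gives 6.8 nM

Compound 2 holds the lowest number of the three, and both of its steps lie beyond the scatter: a 2.2-fold lower number from compound 1 to compound 2 (0.34 log units; beyond the scatter) and a 5.7-fold higher number from compound 2 to compound 3 (0.75 log units; beyond the scatter). The next compound to be read is compound 4 `CC1=NC(C)=C(C(=O)OCCCN2C(=O)c3ccccc3S2(=O)=O)C(c2ccccc2Cl)/C1=C(\O)OC(C)C`, which differs from compound 2 in one place: chloro in place of nitro on an aromatic carbon. In words, this is chloro in place of nitro on an aromatic carbon, ortho to a large group, or 2-nitrophenyl to 2-chlorophenyl.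

For the measured compounds named here, no measured step touches this place. All three steps change the group on the oxygen, the third being a 2.6-fold higher number from compound 1 to compound 3 (0.42 log units; beyond the scatter), so they bear only indirectly, as a guide to how far single changes have moved this assay in this series. All three were modest. The data give no firm direction for the new change. A slight rise is favoured only in that compound 2 at 1.2 nM already sits lowest, and a step within or near the scatter is expected. The estimated step is a 1.7-fold higher number from compound 2 to compound 4 (0.22 log units; within the scatter) and remains an expectation. For compound 4 the expected value is 2 nM, with an estimated range of 0.6 nM to 7 nM in this assay.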

Compound 4, half-maximal inhibitory concentration: 1.3 nM
Estimate against measurement, compound 4: 1.5-fold (0.19 log units) above, and the stated range covers the measured number.
By their numbers in this assay, from the lowest: compounds 2, 4 and 1 (each within the scatter of the next, the first and the last beyond it); then compound 3.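

In this assay the change at this aromatic carbon gives a 1.1-fold higher number from compound 2 to compound 4 (0.03 log units; within the scatter) and so, with isopropyl held on the oxygen, 2-nitrophenyl and 2-chlorophenyl cannot be told apart. For this pair, the nitro group with its 3 heavy atoms and 2 hydrogen-bond acceptors is not needed to keep the number low, since chloro with 1 heavy atom and no hydrogen-bond acceptors reads the same within the scatter, whereas changes on the oxygen such as a 2.2-fold lower number from compound 1 to compound 2 (0.34 log units; beyond the scatter) lie beyond it. No measurement at hand accounts for the two groups reading alike.

From the compounds shown here alone, whether this match holds with other groups on the oxygen remains open, as the chloro change is read only against isopropyl and not against the ethyl of compound 1 or the (oxolan-2-yl)methyl of compound 3. Also open, going by these compounds, is how this assay responds to a methoxy group, an amine or a carboxylic acid at this same place on the phenyl ring.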